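The compounds below may be only part of what the source reports. "The series", "measured", "known", "first", "only" and "open" are said of these compounds alone.

Compound 1, `Cc1cccc(C(=O)n2c(-c3cn(-c4ccccc4)nc3-c3ccc(C(F)(F)F)cc3)nc3ccccc32)c1`: 154000 nM
Compound 2, `Cc1cncc(C(=O)n2c(-c3cn(-c4ccccc4)nc3-c3ccc(F)cc3)nc3ccccc32)c1`: 119000 nM

Of the compounds shown here, two have so far been measured in an ADME assay on HEK-293T cells (Homo sapiens) for cytotoxicity, read by MTT assay, with a stated time of 24 h; a higher number here means that more compound is tolerated, a lower number that less compound is tolerated. Compound 1 gives the higher of the two numbers, but its nearest neighbour, compound 2, lies only a small distance away, a gap that falls within the scatter of repeated measurements, so the two cannot be ranked against each other. Both compounds share the same core and differ in the aromatic group carried by the carbonyl carbon and in the substituent on the distal phenyl ring.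

Compound 3, `O=C(c1ccncc1)n1c(-c2cn(-c3ccccc3)nc2-c2ccc(C(F)(F)F)cc2)nc2ccccc21`, has not yet been measured in this assay. It is derived from compound 1 by a single change: pyridin-4-yl in place of 3-methylphenyl on a carbonyl carbon. For the measured compounds named here, no step between two measured compounds isolates a change of this kind, so there is no direct precedent to draw on. The closest information is the pair of values from compound 1 and compound 2, which sit within the scatter of each other.

On that basis the step from compound 1 to compound 3 is expected to be a 1.2-fold lower number from compound 1 to compound 3 (0.07 log units; within the scatter), with no movement beyond the scatter anticipated in either direction. Compound 3 is therefore estimated at 130000 nM, within a range from 60000 nM to 280000 nM.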

Compound 3, half-maximal cytotoxic concentration: 135000 nM
Compound 3: middle estimate off by 1.0-fold (0.02 log units), on the low side; the measured number falls inside the stated range.
By their numbers in this assay, from the lowest: compounds 2, 3 and 1 (each within the scatter of the next).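

For the compounds shown here, on the carbonyl carbon whose other neighbour is the aromatic nitrogen, pyridin-4-yl in place of 3-methylphenyl gives a 1.1-fold lower number from compound 1 to compound 3 (0.06 log units; within the scatter) in this assay, and this is the first step that isolates a single place, since compound 1 and compound 2 differ in two. It shows that this position accepts a ring with one hetero atom and one hydrogen-bond acceptor in place of a carbon-only ring carrying a methyl group, with no reading beyond the scatter. No measurement at hand bears on what lies behind this result.

The step exchanges the methyl group and the ring nitrogen together, so the compounds shown cannot separate the two, and a plain phenyl group or a pyridin-4-yl group carrying a methyl group would be needed to part them. Also open, on these data alone, is whether the tolerance at this carbonyl carbon extends to groups of another kind, such as an aliphatic amine, a carboxylic acid or a longer alkyl chain.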